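This account rests on a few compounds, and the source may have more. Where it says the series, first, only, none or still open, it means among the compounds named here.

Measured compounds:
Compound 1 `O=C(O)c1cnc2cc(OCCc3ccc(Br)cc3)ccc2c1O`: in an assay on isolated protein with malate dehydrogenase, cytoplasmic (Sus scrofa) as the target (a lower number here means a stronger inhibitor, a higher number a weaker inhibitor), compound 1 gives 91200 nM.
Compound 2 `CN(C)c1ccc2c(O)c(C(=O)O)cnc2c1`: in this assay compound 2 gives 372000 nM.

Compound 2 stands at the highest of the two numbers. Its nearest neighbour is compound 1, whose number is lower by a gap that lies beyond the usual scatter, so compound 2 is the weaker inhibitor of the pair. Within the data shown here, no single-place step connects the two, so the gap cannot be tied to one change in structure.

Compound 3 `NC(=O)c1ccc2c(O)c(C(=O)O)cnc2c1` has not yet been measured in this assay. It differs from compound 2 in one place: carbamoyl in place of dimethylamino on an aromatic carbon. Among the measured compounds shown here, no measured pair shows the effect of such a change, and nothing beyond the number of compound 2 itself offers a foothold. The chemist therefore expects a step of no more than the usual scatter in either direction, with a slight lean toward a lower number. The expected step from compound 2 to compound 3 is a 1.2-fold lower number from compound 2 to compound 3 (0.09 log units; within the scatter). For compound 3 the chemist expects 300000 nM, within a range from 80000 nM to 1200000 nM.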

Compound 3, half-maximal inhibitory concentration: 603000 nM
Beside the measured number, compound 3's estimate is 2.0-fold (0.30 log units) below it; measured number inside the range.
By their numbers in this assay, from the lowest: compound 1; then compounds 2 and 3 (each within the scatter of the next).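

In this assay, among these compounds, the exchange of dimethylamino for carbamoyl on this aromatic carbon gives the first step that can be read at this position: a 1.6-fold higher number from compound 2 to compound 3 (0.21 log units; within the scatter). The step does not separate the two compounds, so this position tolerates this particular exchange without a change that can be told from repeated measurement, even though carbamoyl brings a hydrogen-bond donor and a double bond outside aromatic rings that dimethylamino lacks, at the same count of heavy atoms. No measurement shown bears on why the two groups give numbers this close.

Among the compounds shown here, whether a primary amine, a carboxylic acid or a longer chain on this aromatic carbon would give a step beyond the scatter stays open, since dimethylamino and carbamoyl are the only two groups joined here by a step that can be read. Also open, going by these compounds, is whether the same exchange would give a step of similar size on a version of the shared core that carries a further group, such as a methyl or a chlorine, on another ring carbon.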